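The source may hold more compounds than are shown below. What is called first, only, known or untested is meant among the compounds shown, and "the series" means these compounds.

In a functional assay on L1210 cells (Mus musculus) for antiproliferative activity (a higher number here means a more potent compound, by a factor of ten per unit of this negative logarithm, a lower number a less potent compound), three compounds have been measured:
compound 1 `CN(C)/N=N/c1ccc([N+](=O)[O-])cc1C(N)=O` gives 3.26;
compound 2 `CN(C)/N=N/c1ccc(S(N)(=O)=O)cc1C(N)=O` gives 3.32;
compound 3 `CN(C)/N=N/c1ccccc1[N+](=O)[O-]` gives 3.28.

Compound 3 stands second of the three on these numbers, though its nearest neighbour compound 1 is lower only within the scatter and compound 2 is higher only within the scatter. Going by the values given here, the one step measured so far, a number 0.06 log units higher from compound 1 to compound 2 (within the scatter), also lies within the scatter. Compound 4 `CN(C)/N=N/c1ccccc1C(N)=O` differs from compound 3 by carbamoyl in place of nitro on an aromatic carbon. Among the compounds with values here, no measured step shows carbamoyl in place of nitro. Because a number 0.06 log units higher from compound 1 to compound 2 (within the scatter) lies within the scatter, only a small step is expected for compound 4, a number 0.02 log units higher from compound 3 to compound 4 (within the scatter). Compound 4 is therefore estimated at 3.3, with a range from 2.9 to 3.7.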

Compound 4, logarithm of the reciprocal of the active concentration, log(1/C): 3.31
Estimate against measurement, compound 4: 0.01 log units below; measured number inside the range.
By their numbers in this assay, from the lowest: compounds 1, 3, 4 and 2 (each within the scatter of the next).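

In this assay, carbamoyl in place of nitro on an aromatic carbon, ortho to a group of 5 heavy atoms, gives a number 0.03 log units higher from compound 3 to compound 4 (within the scatter), so this position does not separate the two groups here. The other ring substituent can also go: hydrogen in place of sulfamoyl gives a number 0.01 log units lower from compound 2 to compound 4 (within the scatter) and hydrogen in place of nitro gives a number 0.05 log units higher from compound 1 to compound 4 (within the scatter). No available evidence accounts for these results. On these data alone, whether an amine or a carboxylic acid at this position would also stay within the scatter remains open.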